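Swapping 3-nitrophenyl for 4-cyanophenyl in compound 3

The compounds below may be only part of what the source reports. "The series", "measured", "known", "first", "only" and "open" are said of these compounds alone.

Measured in a functional assay on HepG2 cells (Homo sapiens) for cytotoxicity, read by MTT assay, with a stated time of 24 h; a lower number here means a stronger inhibitor, a higher number a weaker inhibitor:
- compound 1 `O=C1/C(=C/c2ccccc2F)CN(S(=O)(=O)c2ccc(F)cc2)C/C1=C\c1ccccc1F`: 7220 nM
- compound 2 `N#Cc1ccc(/C=C2\CN(S(=O)(=O)c3ccc(F)cc3)C/C(=C\c3ccc(C#N)cc3)C2=O)cc1`: 11500 nM
- compound 3 `O=C1/C(=C/c2cccc([N+](=O)[O-])c2)CN(S(=O)(=O)c2ccc(F)cc2)C/C1=C\c1ccccc1F`: 7040 nM

Compound 3, at 7040 nM, lies within the usual scatter of both compound 1 and compound 2, so these three numbers cannot be ranked.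

Compound 4 `N#Cc1ccc(/C=C2\CN(S(=O)(=O)c3ccc(F)cc3)C/C(=C\c3ccccc3F)C2=O)cc1` comes from compound 3 by a single change: 4-cyanophenyl in place of 3-nitrophenyl on a double-bonded chain carbon bound to a double-bonded ring carbon. In words, 4-cyanophenyl stands in place of 3-nitrophenyl on a double-bonded chain carbon bound to a double-bonded ring carbon.

Among the compounds with values here, no measured step involves 4-cyanophenyl directly. Within the data shown here, the one measured step changes the same kind of group: a 1.0-fold lower number from compound 1 to compound 3 (0.01 log units; within the scatter), which lies within the scatter. Compound 2, which also carries 4-cyanophenyl, gives 11500 nM, and that number is also within the scatter of compound 3. Of the compounds shown here, three are a thin basis, but nothing measured so far points to a large move, so no change beyond the scatter is expected in this assay.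

The expected step is a 1.2-fold higher number from compound 3 to compound 4 (0.08 log units; within the scatter), a small estimated shift towards the number of compound 2.

Compound 4 is estimated at 8500 nM, with an expected range from 4500 nM to 15000 nM.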

Compound 4, half-maximal inhibitory concentration: 8180 nM
Beside the measured number, compound 4's estimate is 1.0-fold (0.02 log units) above it, within the range that was stated.
By their numbers in this assay, from the lowest: compounds 3, 1, 4 and 2 (each within the scatter of the next).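

Compound 4 puts 4-cyanophenyl and 3-nitrophenyl in direct comparison at this place, on a double-bonded chain carbon bound to a double-bonded ring carbon, and in this assay this single swap stays small (a 1.2-fold higher number from compound 3 to compound 4 (0.07 log units; within the scatter)). It also links 4-cyanophenyl to 2-fluorophenyl in both directions, once when 4-cyanophenyl enters (a 1.1-fold higher number from compound 1 to compound 4 (0.05 log units; within the scatter)) and once when 2-fluorophenyl enters (a 1.4-fold lower number from compound 2 to compound 4 (0.15 log units; within the scatter)), so the three phenyl groups cannot be told apart by these four compounds, even though the swap from 3-nitrophenyl to 4-cyanophenyl changes the heavy atoms and hydrogen-bond acceptors counted on the group. Nothing at hand explains why the numbers sit so close together.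

Every group shown at this place is a substituted phenyl ring, so it remains open whether a phenyl ring carrying an amine or a carboxylic acid, or a longer carbon chain in place of the ring, would move the number beyond the scatter. As far as these compounds go, it is also open whether this close grouping holds beyond this assay, since these compounds are compared here in that one cell assay alone.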